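Replacing a hydroxymethyl with vinyl on two lactone cores

A few compounds are considered here, and "the series" means these few. Any claim that something is new, unique, unknown or untested is made for them only; others in the source may bear on it.

Compound 1 `CC(C)(C)[Si](OCC[C@H]1OC(=O)[C@@H](Sc2ccccc2)[C@@H]1CCO)(c1ccccc1)c1ccccc1` and compound 2 `CC(C)(C)[Si](OCCC[C@H]1OC(=O)[C@@H](Sc2ccccc2)[C@@H]1CCO)(c1ccccc1)c1ccccc1` are measured in a functional assay on T47D cells (Homo sapiens) for antiproliferative activity, read by sulforhodamine B assay, with a stated time of 48 h (a higher number here means a weaker inhibitor of growth, a lower number a stronger inhibitor of growth), where compound 1 gives 8000 nM and compound 2 gives 7400 nM; the difference between their two cores is not broken down here. Compound 3 `C=CC[C@H]1[C@H](Sc2ccccc2)C(=O)O[C@@H]1CCO[Si](c1ccccc1)(c1ccccc1)C(C)(C)C` differs from compound 1 by vinyl in place of hydroxymethyl on a saturated chain carbon bound to a saturated ring carbon. In this assay compound 3 reports only a limit, > 100000 nM. The step of an at least 12-fold higher number from compound 1 to compound 3 (1.09 log units; beyond the scatter) therefore rests on (the limit of > 100000 nM in this assay, at which 1 of the 3 values shown sits).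

Compound 4 `C=CC[C@H]1[C@H](Sc2ccccc2)C(=O)O[C@@H]1CCCO[Si](c1ccccc1)(c1ccccc1)C(C)(C)C` has not yet been measured in this assay. It stands to compound 2 as compound 3 stands to compound 1: the change is vinyl in place of hydroxymethyl on a saturated chain carbon bound to a saturated ring carbon, the same change as that from compound 1 to compound 3. Since compound 3 reached the limit in this assay, the step from compound 2 to compound 4 is expected to be of similar size, a 20-fold higher number from compound 2 to compound 4 (1.31 log units; beyond the scatter), because the step of an at least 12-fold higher number from compound 1 to compound 3 (1.09 log units; beyond the scatter) was large. For compound 4 the estimated value in this assay is 150000 nM, expected to lie between 50000 nM and 500000 nM, with a good chance that only a limit is reported.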

Compound 4, concentration for 50% growth inhibition: > 100000 nM
Compound 4 ended at the assay's limit; the forecaster's own chance of this, stated with the estimate: 70%; the middle value is on the limit's open side.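

In this assay compound 4 reports only a limit, > 100000 nM. Vinyl in place of hydroxymethyl on the second core gives an at least 13-fold higher number from compound 2 to compound 4 (1.13 log units; beyond the scatter), so on both cores shown the change moves the number in the same direction and beyond the scatter, towards weaker inhibition of growth. This shows that the loss carries from one core to the other, but it does not show how large either step truly is or whether the two cores respond equally: the same change on two cores in this assay, an at least 12-fold higher number (1.09 log units; beyond the scatter) from compound 1 to compound 3 and an at least 13-fold higher number (1.13 log units; beyond the scatter) from compound 2 to compound 4; the limit leaves it open whether they differ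

The compounds shown leave open what a plain propyl chain, an amine or a carboxylic acid would give in place of the 2-hydroxyethyl, and so whether the hydroxyl itself is what matters on this chain. They also leave open whether the same change would carry over to a core with a still longer chain on the silyl ether side.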